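A Change of Aryl Group on the Chain Carbon

A few compounds are considered here, and "the series" means these few. Any claim that something is new, unique, unknown or untested is made for them only; others in the source may bear on it.

The measured compounds and their numbers in a functional assay on P338 cells (Mus musculus) for antiproliferative activity; a lower number here means a stronger inhibitor, a higher number a weaker inhibitor:
compound 1, `COc1ccccc1/C=C/C(=O)c1ccc(OCCn2cc(CN3C(=O)/C=C/C(C)(C)C/C=C(\C)CC/C=C/3C)nn2)cc1O`: 1.1 ug/mL
compound 2, `C/C1=C\CC(C)(C)/C=C/C(=O)N(Cc2cn(CCOc3ccc(C(=O)/C=C/c4ccc(C(C)C)cc4)c(O)c3)nn2)/C(C)=C/CC1`: 1.39 ug/mL
compound 3, `COc1ccc(/C=C/C(=O)c2ccc(OCCCN3C(=O)/C=C/C(C)(C)C/C=C(\C)CC/C=C/3C)cc2)cc1`: 1.3 ug/mL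

Compound 3 stands second highest of the three numbers; compound 2 lies nearest and compound 1 furthest, and both gaps are within the scatter, so the three are not separated by this assay.

Compound 4, `COc1cc(/C=C/C(=O)c2ccc(OCCCN3C(=O)/C=C/C(C)(C)C/C=C(\C)CC/C=C/3C)cc2)cc(OC)c1OC`, differs from compound 3 in one place: 3,4,5-trimethoxyphenyl in place of 4-methoxyphenyl on a double-bonded chain carbon bound to a double-bonded chain carbon. Among the compounds with values here, the only measured step at the same place is the exchange of one aryl group for another, a 1.3-fold higher number from compound 1 to compound 2 (0.10 log units; within the scatter), which stayed within the scatter. On that basis no step beyond the scatter is expected in this assay, in either direction. Compound 4 is therefore expected to give about 1.3 ug/mL, with a range from 0.6 ug/mL to 2.8 ug/mL. The step of no change at the digits printed from compound 3 to compound 4 (within the scatter) is thus estimated to be small.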

Compound 4, half-maximal inhibitory concentration: 0.77 ug/mL
For compound 4 the middle estimate is 1.7-fold (0.23 log units) above the measured one, within the range that was stated.
By their numbers in this assay, from the lowest: compounds 4, 1, 3 and 2 (each within the scatter of the next).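

In this assay the exchange of 4-methoxyphenyl for 3,4,5-trimethoxyphenyl gives a 1.7-fold lower number from compound 3 to compound 4 (0.23 log units; within the scatter) and so stays within the scatter. Within the data shown here, this is a second aryl exchange on a double-bonded chain carbon bound to a double-bonded chain carbon, now on the core of compound 3, and the larger group with its 12 heavy atoms and 3 hydrogen-bond acceptors still yields no separable step. Nothing available accounts for this result. From the compounds shown here alone, whether an aryl group carrying an amine or a carboxylic acid would give a step beyond the scatter at this place remains open.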